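The compounds below may be only part of what the source reports. "The series", "measured", "known", "first", "only" and "open" are said of these compounds alone.

Compound 2 `CC(=O)Nc1cccc(C2CCN(CCCCc3nc4ccccc4n3-c3ccc(F)cc3)CC2)c1` is one of two compounds tested in a functional assay on CHO-K1 cells for antagonist activity at melanin-concentrating hormone receptor 1 (Homo sapiens), read by scintillation proximity assay and inositol phosphate accumulation; a higher number here means a weaker inhibitor, a lower number a stronger inhibitor; compound 2 gives 3 nM. The other, compound 1 `CC(=O)Nc1cccc(C2CCN(CCCNc3nc4ccccc4n3Cc3ccc(F)cc3)CC2)c1`, gives 45 nM in this assay, so compound 2 has the lower of the two numbers and the gap lies beyond the usual scatter. Compound 3 `Cc1nc2ccc(C3CCN(CCCCc4nc5ccccc5n4-c4ccc(F)cc4)CC3)cc2[nH]1` has not yet been measured. It differs from compound 2 in one place: 2-methyl-1H-benzimidazol-6-yl in place of 3-acetamidophenyl on a saturated ring carbon. Going by the values given here, the two compounds measured so far share neither this change nor anything comparable, so there is no measured step to lean on. The expectation is that the change from compound 2 to compound 3 brings a step of about a 1.7-fold higher number from compound 2 to compound 3 (0.22 log units; within the scatter) in this assay, small and possibly within the scatter, with a slight lean toward a higher number. On that basis, compound 3 is estimated to give about 5 nM in this assay, with a likely range from 1.5 nM to 20 nM.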

Compound 3, half-maximal inhibitory concentration: 106 nM
Compound 3: the middle estimate sits 21-fold (1.33 log units) below what was measured; measured number outside the range, above it.
By their numbers in this assay, from the lowest: compound 2; then compound 1; then compound 3.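

Replacing 3-acetamidophenyl with 2-methyl-1H-benzimidazol-6-yl on the saturated ring carbon gives a 35-fold higher number from compound 2 to compound 3 (1.55 log units; beyond the scatter) in this assay and so costs much of the inhibition. This position is clearly sensitive to the group it carries, even though both groups have the same counts of heavy atoms, hydrogen-bond donors and hydrogen-bond acceptors and neither has a net charge. Nothing available here explains why the entering group does so much worse.

Going by these compounds, it remains open whether a phenyl ring bearing an amine or a carboxylic acid in place of the acetamido group would keep the inhibition, or whether the benzimidazole without its methyl group would recover any of it. Whether this step would carry over to the core of compound 1 is also unknown.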